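The source may report more compounds than this note shows. Statements on the series, on what has been measured and on what is new or still open speak of the compounds shown alone.

Series notes. Compound 1 `COc1cccc(/C=C/C[C@H]2C[C@@H]([C@@H](O)c3ccccc3)CO[C@@H]2c2ccccc2)c1` is the reference point of the set. For the measured compounds named here, in a functional assay on HeLa cells (Homo sapiens) for cytotoxicity, read by WST assay, with a stated time of 48 h (on this read-out lower numbers stand for stronger inhibition and higher numbers for weaker inhibition), compound 1 gives 10900 nM, and this is the only number so far recorded. Compound 2 `COc1ccc(/C=C/C[C@H]2C[C@@H]([C@@H](OC(C)=O)c3ccc(OC)c(OC)c3)CO[C@@H]2c2ccc(OC)c(OC)c2)cc1OC` is the second member of the set. In this assay compound 2 reaches only a limit, > 100000 nM, so no number stands for it. Going by the values given here, what can be said of the set is summarised by the limit of > 100000 nM in this assay, at which 1 of the 2 values shown sits, and no measured step between compounds that differ in a single place exists; compound 1 thus stands alone with a value.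

Compound 3 `O=[N+]([O-])c1ccccc1/C=C/C[C@H]1C[C@@H]([C@@H](O)c2ccccc2)CO[C@@H]1c1ccccc1` is not yet measured. It differs from compound 1 as follows: 2-nitrophenyl in place of 3-methoxyphenyl on a double-bonded chain carbon bound to a double-bonded chain carbon. Among the compounds with values here, with no measured step of this kind to lean on, any expectation in this assay rests on compound 1 alone. The change is expected to give a step of a 1.1-fold higher number from compound 1 to compound 3 (0.04 log units; within the scatter) that stays within the scatter or at most slightly beyond it, in either direction. Compound 3 is accordingly estimated at 12000 nM, with a range from 4000 nM to 40000 nM.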

Compound 3, half-maximal inhibitory concentration: 11800 nM
The estimate for compound 3 lay 1.0-fold (0.01 log units) above the measured number, within the range that was stated.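

For the compounds shown here, the first readable step falls at this place: in this assay, 2-nitrophenyl in place of 3-methoxyphenyl on a double-bonded chain carbon bound to a double-bonded chain carbon gives a 1.1-fold higher number from compound 1 to compound 3 (0.03 log units; within the scatter). Compound 1 on its own could not show whether the aromatic group at this place can be exchanged on the shared core, and this pair shows that one such exchange, with a different substituent and a different ring position of that substituent, stays within the usual scatter of the read-out. Nothing measured in the set bears on why the two numbers stay so close.

This single exchange does not tell whether the same holds for other groups at this place, such as an aminophenyl or a carboxyphenyl ring, or for a longer chain carrying the aromatic ring, nor whether the nitro group or its ring position would matter when taken separately. Compound 2 stands at a limit, > 100000 nM, and differs from compound 1 in more than one place, so no step can be read from it.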